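The source may hold more compounds than are shown below. What is called first, only, known or untested is meant among the compounds shown, and "the series" means these compounds.

Measured compounds:
compound 1, `COc1ccc(/C=C/C(=O)CC(C)=O)cc1OC`: 8200 nM
compound 2, `CC(=O)/C=C(O)/C=C/c1ccc(O)c(O)c1`: 7300 nM
compound 3, `Cc1cc(/C=C/c2ccc(O)cc2)on1`: 50200 nM

Within the data shown here, in an ADME assay on HEK293 cells (Homo sapiens) for cytotoxicity, read by MTT assay, with a stated time of 72 h (a lower number here means a stronger inhibitor, a higher number a weaker inhibitor), compound 1 gives 8200 nM, which places it second highest among the three numbers known. Compound 2 gives 7300 nM, a number that lies within the scatter of compound 1, so no order between the two can be read. Compound 3 gives 50200 nM, a clearly higher number, beyond the scatter of compound 1.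

The unmeasured compound 4, `COc1ccc(/C=C/c2cc(C)no2)cc1OC`, keeps the core of compound 1 and changes one place: 3-methyl-1,2-oxazol-5-yl in place of (2-oxopropyl)carbonyl on a double-bonded chain carbon bound to a double-bonded chain carbon. Among the measured compounds shown here, no step between measured compounds of exactly this kind is known. Compound 3, however, also carries a 3-methyl-1,2-oxazol-5-yl on a double-bonded chain carbon and gives the highest number of the set, so a step upward in this assay, beyond the scatter, is expected from compound 1 to compound 4. The expected step is a 3.7-fold higher number from compound 1 to compound 4 (0.56 log units; beyond the scatter). Compound 4 is therefore estimated at 30000 nM, with a range from 10000 nM to 90000 nM.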

Compound 4, half-maximal inhibitory concentration: 63200 nM
The estimate for compound 4 lay 2.1-fold (0.32 log units) below the measured number; low and high end bracket the measured number.
By their numbers in this assay, from the lowest: compounds 2 and 1 (each within the scatter of the next); then compounds 3 and 4 (each within the scatter of the next).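

In this assay, among these compounds, 3-methyl-1,2-oxazol-5-yl in place of (2-oxopropyl)carbonyl on a double-bonded chain carbon bound to a double-bonded chain carbon gives a 7.7-fold higher number from compound 1 to compound 4 (0.89 log units; beyond the scatter), the first direct reading of a single change at this position, which the earlier compounds could not offer. The leaving and entering groups have equal counts of heavy atoms, hydrogen-bond donors and hydrogen-bond acceptors, so those counts alone do not set the number here, while the two groups differ in the ring and in the double bonds outside aromatic rings. Nothing at hand gives a measured reason for the step.

This single step cannot tell whether the rise comes from gaining the 3-methyl-1,2-oxazol-5-yl ring or from losing (2-oxopropyl)carbonyl. It also leaves open where a carboxylic acid or an amine in that place would fall.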